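The source may hold more compounds than are shown below. What is called first, only, known or untested is meant among the compounds shown, and "the series" means these compounds.

Measured so far in a functional assay on NUGC-3 cells (Homo sapiens) for inhibition, read by sulforhodamine B assay, with a stated time of 48 h; a lower number here means a stronger inhibitor of growth, a higher number a weaker inhibitor of growth:

compound 1, `O=C(Nc1ccc(O)cc1)C1NCCc2ccccc21`: 4370 nM
compound 2, `O=C(Nc1cccc(O)c1)C1c2ccccc2CCN1C(=O)c1ccc(Cl)cc1`: > 10000 nM, a limit
compound 3, `O=C(Nc1ccc(O)cc1)c1nccc2ccccc12`: > 10000 nM, a limit

For the measured compounds named here, compound 1 is the only member with a number in this assay, 4370 nM. Compound 2 returns no number, only a limit, > 10000 nM. Compound 3 likewise returns only a limit, > 10000 nM. Going by the values given here, the set therefore rests on (the limit of > 10000 nM in this assay, at which 2 of the 3 values shown sit), and compound 1 alone anchors it with a measured value; no pair of measured compounds differs in a single place, so no step within the measured set can be read.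

The next compound, compound 4, `COc1ccc(NC(=O)C2NCCc3ccccc32)cc1`, is the simplest variation on compound 1: methyl in place of hydrogen on an oxygen on an aromatic ring. Nothing in the measured set tests this change, so the expectation is held loosely. The step from compound 1 to compound 4 is expected to be small, if anything toward weaker growth inhibition, and may well fall within the scatter: a 1.5-fold higher number from compound 1 to compound 4 (0.17 log units; within the scatter). Compound 4 is estimated at 6500 nM in this assay, with a range from 2000 nM to 20000 nM, and a real chance that it, too, reports only a limit.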

Compound 4, concentration for 50% growth inhibition: > 10000 nM
Compound 4: only a limit was reported; the forecaster's own chance of this, stated with the estimate: 30%; at least 1.5-fold (0.18 log units) between middle value and limit.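

For the compounds shown here, the hydroxy to methoxy change supplies the first step that can be read, and it is not small: an at least 2.2-fold higher number from compound 1 to compound 4 (0.35 log units; beyond the scatter). In this assay compound 4 gives > 10000 nM, which is a limit. On this single pair, the free hydroxy of compound 1 is the only form of this oxygen that returns a number, and methyl in place of its hydrogen is not tolerated as a neutral swap, with the set now resting heavily on one reading: the limit of > 10000 nM in this assay, at which 3 of the 4 values shown sit.

The compounds shown leave open whether the drop belongs to methyl alone or to any group on that oxygen, such as an ethyl or a longer chain, and whether an amine or a carboxylic acid in place of the hydroxy would keep a measurable number. Going by these compounds alone, with only one pair on the shared core, nothing yet shows whether this result would hold for other changes on the aromatic ring or on the ring nitrogen of compound 1.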